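Kinetic Solubility Across Three Amides and a Fourth

This account rests on a few compounds, and the source may have more. Where it says the series, first, only, none or still open, it means among the compounds named here.

Measured in a physicochemical assay for solubility, in phosphate buffer, measured as kinetic solubility, with a stated time of 1 h, at pH 7.4; on this read-out lower numbers stand for lower solubility and higher numbers for higher solubility:
compound 1, `COc1ccc2nc(C(F)(F)F)cc(OCC(=O)Nc3cc(C)cc(C)c3)c2c1`, gives 15000 nM
compound 2, `COc1ccc2nc(C)cc(OC(C)(C)C(=O)Nc3cc(C)cc(C)c3)c2c1`, gives 20000 nM
compound 3, `COc1ccc2nc(C)cc(OCC(=O)Nc3cc(C)ccc3OC)c2c1`, gives 9500 nM

Compound 3 sits at the lowest of the three numbers. Its gap to compound 1 lies within the scatter, so nothing can be said of their order; its gap to compound 2 lies beyond the scatter, and compound 2 shows the higher value. Compound 4, `COc1ccc2nc(C)cc(OCC(=O)Nc3noc(C)c3C)c2c1`, has not yet been measured in this assay. It differs from compound 3 in one place: 4,5-dimethyl-1,2-oxazol-3-yl in place of 2-methoxy-5-methylphenyl on an amide-type nitrogen. Within the data shown here, no step between measured compounds is available to lean on, so only a modest move in this assay is expected, if any, with the estimate for compound 4 leaning slightly upward but staying within the scatter: a 1.6-fold higher number from compound 3 to compound 4 (0.20 log units; within the scatter). Compound 4 is therefore estimated at 15000 nM, within a range from 6000 nM to 40000 nM.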

Compound 4, solubility: 196000 nM
Compound 4: middle estimate off by 13-fold (1.12 log units), on the low side; measured number outside the range, above it.
By their numbers in this assay, from the lowest: compounds 3, 1 and 2 (each within the scatter of the next, the first and the last beyond it); then compound 4.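

In this assay, the group on the amide-type nitrogen proved able to move the read-out far: 4,5-dimethyl-1,2-oxazol-3-yl in place of 2-methoxy-5-methylphenyl gives a 21-fold higher number from compound 3 to compound 4 (1.31 log units; beyond the scatter) and stands as a large step, well beyond the scatter. Among these compounds, the earlier compounds offered no step in one place, so this is the first measure of how much a single change can do here. Nothing at hand accounts for the size of this step.

On these data alone, whether it belongs to the five-membered ring or to its two methyl groups stays open. So does how an unsubstituted 1,2-oxazol-3-yl, or a phenyl carrying an amine, would read on this nitrogen.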